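Working notes: benzyl for methoxyphenyl at the ring nitrogen

The source may report more compounds than this note shows. Statements on the series, on what has been measured and on what is new or still open speak of the compounds shown alone.

Measured compounds:
compound 1 `CCOC(=O)CNc1nc(Nc2cccc(OC)c2)ncc1[N+](=O)[O-]`: 36100 nM
compound 2 `CCOC(=O)CN(Cc1ccccc1)c1nc(NCc2ccccc2)ncc1[N+](=O)[O-]`: > 100000 nM
compound 3 `CCOC(=O)CNc1nc(Nc2ccc(OC)cc2)ncc1[N+](=O)[O-]`: > 100000 nM

In a functional assay on A549 cells (Homo sapiens) for antiproliferative activity, read by MTT assay, with a stated time of 48 h (a lower number here means a stronger inhibitor, a higher number a weaker inhibitor), compound 1 gives 36100 nM. For compound 2 the value > 100000 nM is a limit of the assay, not a number. For compound 3 the value > 100000 nM is likewise a limit. Compound 3 therefore stands at the weak end of what is shown: the single measured step, an at least 2.7-fold higher number from compound 1 to compound 3 (0.44 log units; beyond the scatter), runs from the only numeric value up to the limit, and compound 3 sits at the limit of > 100000 nM in this assay, at which 2 of the 3 values shown sit.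

Compound 4 `CCOC(=O)CNc1nc(NCc2ccccc2)ncc1[N+](=O)[O-]` differs from compound 3 as follows: benzyl in place of 4-methoxyphenyl on a nitrogen on an aromatic ring. Among the compounds with values here, no measured step covers this swap; an at least 2.7-fold higher number from compound 1 to compound 3 (0.44 log units; beyond the scatter) concerns the two methoxyphenyl isomers and fixes only the starting point. Compound 2 carries benzyl at the same nitrogen together with a second benzyl and also returns a limit.

From a limit no size of step can be read in this assay, so compound 4 is expected to remain near the limit. Compound 4 is estimated at 100000 nM (range 30000 nM to 300000 nM). The expected step is a number no higher from compound 3 to compound 4 (the limit leaves the size open).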

Compound 4, half-maximal inhibitory concentration: 74400 nM
For compound 4 the middle estimate is 1.3-fold (0.13 log units) above the measured one, and the stated range covers the measured number.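

At the nitrogen on an aromatic ring, benzyl in place of 3-methoxyphenyl now has a readable size in this assay, namely a 2.1-fold higher number from compound 1 to compound 4 (0.31 log units; beyond the scatter), a modest step. Compound 4 also shows that a numeric value at this position does not depend on a methoxyphenyl group, although 74400 nM remains a weak result. The other two steps each start from a limit of the assay and give only a floor, not a size: an at least 1.3-fold lower number from compound 3 to compound 4 (0.12 log units; that floor lies within the scatter), and an at least 1.3-fold lower number from compound 2 to compound 4 (0.12 log units; that floor lies within the scatter).

Open, as far as these compounds go, is whether a longer chain such as phenylethyl, or an amine such as morpholine, in place of benzyl at this nitrogen would give a lower number. Also open, from the compounds shown here alone, is whether a carboxylic acid in place of the ethyl ester would move the number in either direction.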